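Changing the Amide Group of Compound 1

The source may hold more compounds than are shown below. What is called first, only, known or untested is meant among the compounds shown, and "the series" means these compounds.

Compound 1 (`COc1cc([C@@H]2C[C@]2(CO)C(=O)Nc2ccccc2Cl)cc(OC)c1OC`) is the starting point. Going by the values given here, in a functional assay on K562 cells (Homo sapiens) for cytotoxicity, read by MTT assay, with a stated time of 48 h (on this read-out lower numbers stand for stronger inhibition and higher numbers for weaker inhibition), compound 1 gives 16900 nM as its only single number, and a further entry carries no single number. In this assay compound 2 (`CCOC(=O)C1(C(=O)NCc2ccc(F)cc2)CC1c1cc(OC)c(OC)c(OC)c1`) gives 45100 nM; 43100 nM (2 entries) ("the higher reading of the two", so the weaker inhibition). Compound 3 (`COc1cc([C@@H]2C[C@]2(CO)C(=O)NCc2ccc(C)cc2)cc(OC)c1OC`) keeps the core of compound 1 but alters the amide (4-methylbenzyl in place of 2-chlorophenyl on an amide-type nitrogen): 4-methylbenzyl in place of 2-chlorophenyl on an amide-type nitrogen. Among the compounds with values here, no measured pair shows this exact change. The amide nitrogen of compound 2 also bears a benzyl group, and its reading of 45100 nM; 43100 nM (2 entries) points toward a modest weakening rather than a large shift. The expected step is a 1.7-fold higher number from compound 1 to compound 3 (0.22 log units; within the scatter) toward weaker inhibition. For compound 3 the estimated value is 28000 nM with 11000 nM to 70000 nM as the expected range.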

Compound 3, half-maximal inhibitory concentration: > 100000 nM
Compound 3: only a limit was reported (the forecaster's own chance of this, stated with the estimate: 10%); middle value at least 3.5-fold (0.55 log units) from the limit.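

Going by these compounds alone, this is the first direct pair at the amide nitrogen, and it shows that the group there matters: 4-methylbenzyl in place of 2-chlorophenyl gives an at least 5.9-fold higher number from compound 1 to compound 3 (0.77 log units; beyond the scatter), toward weaker inhibition. In this assay compound 3 gives > 100000 nM, which is a limit of the assay and not a number. The step therefore sets only a minimum, and its full size cannot be read: the limit of > 100000 nM in this assay, at which 1 of the 3 values shown sits.

The change alters two things at once, replacing a phenyl group with a benzyl group and a chlorine with a methyl, so this pair cannot say which of them counts. A 2-chlorobenzyl group or a 4-methylphenyl group on the same nitrogen would separate the two, and the compounds shown leave open how either would read.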